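This account rests on a few compounds, and the source may have more. Where it says the series, first, only, none or still open, it means among the compounds named here.

Measured so far:
- compound 1 `Cc1cc(F)ccc1-c1ncnc2c1cnn2CCN1CCCCC1` — in an assay on HEK293 cells for displacement of a labelled ligand from Sigma non-opioid intracellular receptor 1 (Homo sapiens), read by scintillation counting, with a stated time of 120 min (a lower number here means a stronger inhibitor, a higher number a weaker inhibitor), compound 1 gives 48 nM
- compound 2 `c1cc(-c2ncnc3c2cnn3CCN2CCCCC2)ccn1` — in this assay compound 2 gives 1720 nM

Going by the values given here, compound 2 stands at the highest of the two numbers; its only neighbour is compound 1, and the step of a 36-fold higher number from compound 1 to compound 2 (1.55 log units; beyond the scatter) is a large one, well beyond the scatter. The step to compound 3 `Cn1cccc1-c1ncnc2c1cnn2CCN1CCCCC1` is 1-methyl-1H-pyrrol-2-yl in place of pyridin-4-yl on an aromatic carbon. Among the compounds with values here, no measured step covers this particular exchange; the one step that bears on the position, a 36-fold higher number from compound 1 to compound 2 (1.55 log units; beyond the scatter), shows only that swapping the aromatic group at this carbon moves the number a great deal, not which way a five-membered ring will move it. Compound 3 is expected to give a number somewhat lower than compound 2 in this assay, with the step of a 5.7-fold lower number from compound 2 to compound 3 (0.76 log units; beyond the scatter) held as an expectation only. The estimate for compound 3 is 300 nM, within a range from 70 nM to 1300 nM.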

Compound 3, inhibition constant: 31 nM
Compound 3: the middle estimate sits 9.7-fold (0.99 log units) above what was measured, and the stated range ends above it.
By their numbers in this assay, from the lowest: compounds 3 and 1 (each within the scatter of the next); then compound 2.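

At this aromatic carbon of the shared core, the change read in this assay as a 55-fold lower number from compound 2 to compound 3 (1.74 log units; beyond the scatter) shows that the high number of compound 2 does not extend to every aromatic ring with one nitrogen, since 1-methyl-1H-pyrrol-2-yl has the same heavy-atom and acceptor counts as pyridin-4-yl. The comparison given by a 1.5-fold lower number from compound 1 to compound 3 (0.19 log units; within the scatter) does not separate 1-methyl-1H-pyrrol-2-yl from 4-fluoro-2-methylphenyl, so a five-membered and a six-membered aromatic ring are both compatible with a low number here. No evidence is available to explain why pyridin-4-yl differs from these two groups.

Compound 1 and compound 3 both carry a methyl group and compound 2 does not, so an unsubstituted phenyl or 1H-pyrrol-2-yl group would be needed to test whether that methyl matters. A pyridin-3-yl or pyridin-2-yl group would show whether the location of the ring nitrogen matters.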